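Replacing the methoxy on the thiophene of compound 1

The source may hold more compounds than are shown below. What is called first, only, known or untested is meant among the compounds shown, and "the series" means these compounds.

Compound 1 `COc1ccc(S(=O)(=O)NC(=O)Nc2ccc(Cl)cc2)s1` stands highest of the three compounds measured in a functional assay on the whole organism (6C3HED cells, Mus musculus) for inhibition, at a dose of 150 mg/kg by the oral route (on this read-out lower numbers stand for less inhibition and higher numbers for more inhibition at the one dose given (going by the name of the read-out)), where compound 1 gives 93%. Compound 2 `CC(C)(C)c1ccc(S(=O)(=O)NC(=O)Nc2ccc(Cl)cc2)s1` gives 7%, and compound 3 `CCc1ccsc1S(=O)(=O)NC(=O)Nc1ccc(Cl)cc1` gives 21%. Both steps away from compound 1 are large falls: a number 86 percentage points lower from compound 1 to compound 2 (beyond the scatter), and a number 72 percentage points lower from compound 1 to compound 3 (beyond the scatter).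

Compound 4 `Cc1cc(S(=O)(=O)NC(=O)Nc2ccc(Cl)cc2)sc1C` has not yet been measured. It differs from compound 1 in one place: 4,5-dimethylthiophen-2-yl in place of 5-methoxythiophen-2-yl on a sulfonyl sulfur. Both measured steps bear on this change, since each of them also did away with the methoxy group of compound 1, one through tert-butyl in place of methoxy on an aromatic carbon, the other through 3-ethylthiophen-2-yl in place of 5-methoxythiophen-2-yl on a sulfonyl sulfur, and each was a large fall in this assay. A large fall is therefore expected for compound 4 as well, a number 68 percentage points lower from compound 1 to compound 4 (beyond the scatter). Compound 4 is estimated to give 25% in this assay, with an expected range from 5% to 60%.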

Compound 4, a percentage reported as inhibition, in the whole organism at one dose (the size of the read-out at that dose, not a potency): 42%
For compound 4 the middle estimate is 17 percentage points below the measured one, and the stated range covers the measured number.
By their numbers in this assay, from the lowest: compound 2; then compound 3; then compound 4; then compound 1.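

Even with the same number of heavy atoms as the group it replaces, 4,5-dimethylthiophen-2-yl on the sulfonyl sulfur does not keep the response of compound 1 in this assay, with a number 51 percentage points lower from compound 1 to compound 4 (beyond the scatter) and a large fall for this third methoxy-free compound. The loss of the methoxy group therefore does not fix the response at one low level, since the change of thiophene substituents gives a number 21 percentage points higher from compound 3 to compound 4 (beyond the scatter) and a modest rise. Thus, among these compounds, the alkyl pattern on the thiophene also shapes the result, although none of them matches compound 1. The data offer no explanation for either step.

From the compounds shown here alone, it remains open whether an amine, a hydroxyl or an ethoxy group in place of the methoxy would hold the response of compound 1. The compounds shown also leave open how a single methyl group on the thiophene would fare.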